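The source may hold more compounds than are shown below. What is called first, only, known or untested is meant among the compounds shown, and "the series" means these compounds.

Working notes on the series.

Two compounds of the shared core have numbers in a functional assay (Jurkat cells) for inhibition, with Homo sapiens as the target, with a stated time of 48 h; a lower number here means a stronger inhibitor, a higher number a weaker inhibitor. Compound 1 `O=C(/C=C/c1ccc(Br)cc1)Oc1ccc(/C=C2\CCCCC2=O)cc1` gives 19800 nM in this assay. Compound 2 `CN(C)CC1CCC/C(=C\c2ccc(OC(=O)/C=C/c3ccc(Br)cc3)cc2)C1=O` gives 4470 nM in this assay, and among the two measured compounds it stands at the lowest number. For the measured compounds named here, the one measured step, a 4.4-fold lower number from compound 1 to compound 2 (0.65 log units; beyond the scatter), is the (dimethylamino)methyl in place of hydrogen on a saturated ring carbon.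

Compound 3 `CN(C)CC1CCC/C(=C\c2ccc(OC(=O)c3ccc(Cl)cc3)cc2)C1=O` keeps that (dimethylamino)methyl group and differs from compound 2 elsewhere: 4-chlorophenyl in place of 2-(4-bromophenyl)ethenyl on a carbonyl carbon. Going by the values given here, no measured step touches the group on the carbonyl carbon; the only step on record sits on the saturated ring carbon, so it does not bear on this change. Nothing in the series therefore points in either direction, and the expectation is a step no larger than the scatter, a 1.0-fold higher number from compound 2 to compound 3 (0.00 log units; within the scatter), with a wide range to reflect the lack of a comparable step. For compound 3 the estimate in this assay is 4500 nM, expected to fall between 1400 nM and 14000 nM.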

Compound 3, half-maximal inhibitory concentration: 3500 nM
The estimate for compound 3 lay 1.3-fold (0.11 log units) above the measured number; low and high end bracket the measured number.
By their numbers in this assay, from the lowest: compounds 3 and 2 (each within the scatter of the next); then compound 1.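

For the compounds shown here, the replacement of 2-(4-bromophenyl)ethenyl by 4-chlorophenyl on a carbonyl carbon gives the first reading at this position: in this assay, it is a 1.3-fold lower number from compound 2 to compound 3 (0.11 log units; within the scatter). With the (dimethylamino)methyl group kept, the ester partner can therefore lose its double bond outside aromatic rings and exchange bromine for chlorine, yet compound 2 and compound 3 remain within the scatter of each other in this assay. No supporting measurement is available to explain this outcome.

The step changes the double bond and the halogen together, so it cannot show whether each change alone would leave the number within the scatter or whether two larger effects offset one another; a plain 4-bromophenyl or a 2-(4-chlorophenyl)ethenyl group on the carbonyl carbon would separate them. Going by these compounds, it also remains open whether 4-chlorophenyl behaves the same way without the (dimethylamino)methyl group, or with a cyclic amine such as morpholin-4-ylmethyl on the saturated ring carbon.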